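Swapping the aryl ketone: furan to fluorophenyl

The compounds below may be only part of what the source reports. "The series", "measured", "known", "first", "only" and "open" are said of these compounds alone.

Compound 1 `O=C(/C=C/c1ccc2c(c1)B(O)OC2)c1ccco1` carries a furan-2-yl ring on the carbonyl carbon of its enone. In a functional assay on MDA-MB-231 cells (Homo sapiens) for cytotoxicity, read by MTT assay, with a stated time of 48 h (a higher number here means a weaker inhibitor, a lower number a stronger inhibitor), compound 1 gives 7300 nM. For the measured compounds named here, that is the higher of the two numbers recorded so far; the only comparison is compound 2 `Cc1ccc(C(=O)/C=C/c2ccc3c(c2)B(O)OC3)cc1`, which in this assay gives 6500 nM, so the two are separated by a 1.1-fold lower number from compound 1 to compound 2 (0.05 log units; within the scatter), a gap that the usual repeat scatter of the assay fully covers.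

Compound 3 `O=C(/C=C/c1ccc2c(c1)B(O)OC2)c1cccc(F)c1` has not yet been measured. Its difference from compound 1 is 3-fluorophenyl in place of furan-2-yl on a carbonyl carbon. Going by the values given here, the one step that bears on this is the replacement at the same carbonyl carbon that led to compound 2, where a six-membered carbon-only aromatic ring also took the place of furan-2-yl and produced only a 1.1-fold lower number from compound 1 to compound 2 (0.05 log units; within the scatter). With nothing else to draw on, no shift beyond the scatter is expected in this assay for compound 3 either. Compound 3 is therefore estimated at 6500 nM, with a plausible range from 3000 nM to 14000 nM. This corresponds to an expected step of a 1.1-fold lower number from compound 1 to compound 3 (0.05 log units; within the scatter).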

Compound 3, half-maximal inhibitory concentration: 3000 nM
Compound 3: the middle estimate sits 2.2-fold (0.34 log units) above what was measured; low and high end bracket the measured number.
By their numbers in this assay, from the lowest: compound 3; then compounds 2 and 1 (each within the scatter of the next).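

The carbonyl carbon of the enone had looked indifferent when only compounds 1 and 2 could be compared, but it does respond in this assay: placing 3-fluorophenyl there gives a 2.4-fold lower number from compound 1 to compound 3 (0.39 log units; beyond the scatter) and, set against 4-methylphenyl, gives a 2.2-fold lower number from compound 2 to compound 3 (0.34 log units; beyond the scatter) as well. For the compounds shown here, both steps are modest, yet they are the first beyond the scatter at this place, and compound 2 and compound 3 both carry a six-membered aromatic ring of carbon only, so having such a ring in place of furan-2-yl does not by itself fix the number. Nothing available explains why compound 3 stands apart from the other two.

Whether the fluorine itself accounts for these steps remains open, and a plain phenyl, a 4-fluorophenyl or a chlorophenyl group on the same carbonyl carbon would bear on that. Also open, from the compounds shown here alone, is how a ring carrying an amine or a carboxylic acid would read at this place, and whether the modest steps seen here would grow or vanish with such groups.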